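Removing the chloropropyl chain from a triazole-bearing lactone

The compounds below may be only part of what the source reports. "The series", "measured", "known", "first", "only" and "open" are said of these compounds alone.

Measured compounds: compound 1 `C[Si](C)(C)c1cn(C[C@H](O)[C@H]2OC(=O)C(OCc3ccccc3)=C2OCc2ccccc2)nn1`, 19200 nM; compound 2 `O=C1O[C@H]([C@@H](O)Cn2cc(CCCCl)nn2)C(OCc2ccccc2)=C1OCc1ccccc1`, 29000 nM.

In a functional assay on A549 cells (Homo sapiens) for antiproliferative activity, read by MTT assay, with a stated time of 72 h (a lower number here means a stronger inhibitor, a higher number a weaker inhibitor), compound 2 gives the highest of the two numbers, and its nearest neighbour, compound 1, lies within the scatter of it, so no order between them is shown. Compound 3 `O=C1O[C@H]([C@@H](O)Cn2ccnn2)C(OCc2ccccc2)=C1OCc1ccccc1` differs from compound 2 by hydrogen in place of 3-chloropropyl on an aromatic carbon. Among the measured compounds shown here, the only measured step, a 1.5-fold higher number from compound 1 to compound 2 (0.18 log units; within the scatter), exchanged one group of four heavy atoms for another and changed little; no step removes a group outright. Compound 3 is therefore expected near compound 2, with an estimated step of a 1.4-fold higher number from compound 2 to compound 3 (0.14 log units; within the scatter), giving an expected 40000 nM within 15000 nM to 110000 nM.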

Compound 3, half-maximal inhibitory concentration: > 100000 nM
Compound 3: a limit, no number (the forecaster's own chance of this, stated with the estimate: 30%); middle value at least 2.5-fold (0.39 log units) from the limit.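

In this assay compound 3 stands at a limit, not a number: the limit of > 100000 nM in this assay, at which 1 of the 3 values shown sits. Hydrogen on this aromatic carbon of the five-membered aromatic ring with 3 nitrogen gives an at least 3.4-fold higher number from compound 2 to compound 3 (0.53 log units; beyond the scatter) in place of 3-chloropropyl, and an at least 5.2-fold higher number from compound 1 to compound 3 (0.71 log units; beyond the scatter) in place of the silicon-bearing group. This position, where exchanging one group for the other showed no change, thus responds when the group is removed outright. Going by these compounds, the true size of these steps stays open. So does whether a plain propyl chain, a longer chain or an amine on this carbon would serve as well.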